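The source may hold more compounds than are shown below. What is called first, only, known or untested is meant among the compounds shown, and "the series" means these compounds.

Compound 3 `O=C(O)C[C@H](NC(=O)CN(c1nc(Cl)nc2[nH]cnc12)C1CC1)C(=O)O` gives 11.6% in a functional assay on the whole organism (Tail, strain ICR) with Mus musculus as the target, in the tail flick test, with a stated time of 150 min, at a dose of 25 umol/kg by the oral route; on this read-out lower numbers stand for a weaker effect and higher numbers for a stronger effect at the one dose given. Of the other measured compounds, compound 1 `O=C(CN(c1nc(Cl)nc2[nH]cnc12)C1CC1)N[C@@H](CO)C(=O)O` gives 18.8% and compound 2 `NCCCC[C@H](NC(=O)CN(c1nc(Cl)nc2[nH]cnc12)C1CC1)C(=O)O` gives 11.6%, so all three numbers sit close together: a number 7.2 percentage points lower from compound 1 to compound 3 (within the scatter) and no change at the digits printed from compound 2 to compound 3 (within the scatter). Compound 4 `CSCC[C@H](NC(=O)CN(c1nc(Cl)nc2[nH]cnc12)C1CC1)C(=O)O` differs from compound 3 at a single place: (methylsulfanyl)methyl in place of carboxy on a saturated chain carbon, two bonds along the chain from an amide-type nitrogen and a carbonyl carbon. For the measured compounds named here, the steps that bear on this change are the earlier swaps at the same place, a number 7.2 percentage points lower from compound 1 to compound 2 (within the scatter), a number 7.2 percentage points lower from compound 1 to compound 3 (within the scatter) and no change at the digits printed from compound 2 to compound 3 (within the scatter), none of them beyond the scatter. Another group at this place is therefore expected to leave the read-out about where it is, and a number 2.4 percentage points higher from compound 3 to compound 4 (within the scatter) is expected to stay within the scatter. Compound 4 is accordingly estimated at 14%, between 4% and 26%.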

Compound 4, a percentage reported as activity, at one dose (the size of the read-out at that dose, not a potency): 4.14%
Compound 4: the middle estimate sits 9.9 percentage points above what was measured; the measured number falls inside the stated range.
By their numbers in this assay, from the lowest: compounds 4, 2, 3 and 1 (each within the scatter of the next, the first and the last beyond it).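

The change to (methylsulfanyl)methyl produces the first gap beyond the scatter at this position, a modest one (a number 14.7 percentage points lower from compound 1 to compound 4 (beyond the scatter)), whereas the earlier swaps here all stayed within it. The same group remains within the scatter of the other two compounds (a number 7.5 percentage points lower from compound 3 to compound 4 (within the scatter); a number 7.5 percentage points lower from compound 2 to compound 4 (within the scatter)), so only the two ends of the series are separated. No measurement shown explains this step. From the compounds shown here alone, it remains open whether the sulfur matters, since a plain butyl chain at this place could show whether an all-carbon group reads like compound 4 or compound 1.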